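The source may hold more compounds than are shown below. What is called first, only, known or untested is meant among the compounds shown, and "the series" means these compounds.

Measured compounds and their largest response in the calcium assay:

Compound 1, `Brc1ccc(N2CCCNCCC2)cn1`, 139%
Compound 2, `c1cncc(N2CCCNCCC2)c1`, 78%
Compound 3, `Clc1ncc(N2CCCNCC2)cc1Br`, 85%

In an assay on HEK293 cells with Neuronal acetylcholine receptor; alpha4/beta2 (Homo sapiens) as the target, read by FLIPR and calcium flux (a lower number here means a smaller maximal response, a higher number a larger maximal response), compound 2 gives the lowest of the three numbers. Its value lies within the usual scatter of compound 3, while compound 1 stands well above it, as the step of a number 61 percentage points lower from compound 1 to compound 2 (beyond the scatter) shows. Compound 4, `Brc1cncc(N2CCCNCCC2)c1`, differs from compound 2 by bromo in place of hydrogen on an aromatic carbon. Compound 4 thus carries a bromo again on the core of compound 2, though not the bromo of compound 1. Going by the values given here, the only step that bears on this is the large drop seen when the bromo of compound 1 was removed. Compound 4 is therefore expected to rise, a number 34 percentage points higher from compound 2 to compound 4 (beyond the scatter), to an estimated 112% with a range from 82% to 145%.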

Compound 4, largest response reached (reported as efficacy), in percent of the reference or control that the assay uses: 73%
Estimate against measurement, compound 4: 39 percentage points above, outside the stated range (below it).
By their numbers in this assay, from the lowest: compounds 4, 2 and 3 (each within the scatter of the next, the first and the last beyond it); then compound 1.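

In this assay, bromo placed two atoms from the ring nitrogen, meta to the group of 8 heavy atoms, gives a number 5 percentage points lower from compound 2 to compound 4 (within the scatter), so here the change leaves the maximal response unaltered. The large step of a number 61 percentage points lower from compound 1 to compound 2 (beyond the scatter) therefore does not hold for bromo at every aromatic carbon of this ring, and the effect depends on where the bromo sits. Nothing available explains why the two places differ. On these data alone, whether an amine or a methoxy group at this position would shift the response remains open. So does whether any group here can reach the level of compound 1.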